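This account rests on a few compounds, and the source may have more. Where it says the series, first, only, none or still open, it means among the compounds named here.

Measured compounds in the series:
compound 1 `COc1ccc(/C(=C(/CCN=[N+]=[N-])c2ccccc2)c2ccccc2)cc1` – "not active" (no number reported)
compound 2 `COc1ccc(/C(=C(/CCNC(=O)Oc2ccccc2)c2ccccc2)c2ccccc2)cc1` – "not active" (no number reported)
compound 3 `COc1ccc(/C(=C(/CCNC(=O)N2CCOCC2)c2ccccc2)c2ccccc2)cc1` – > 50000 nM

All three were run in a functional assay on MCF7 cells (Homo sapiens) for cytotoxicity, read by MTT assay, with a stated time of 72 h; a higher number here means a weaker inhibitor, a lower number a stronger inhibitor. Compound 1 is recorded as "not active" (no number reported) without a number. Compound 2 is recorded as "not active" (no number reported), again without a number. Compound 3 reaches only the limit of the assay, > 50000 nM, and no number is given. Within the data shown here, compound 3 therefore stands at the limit of > 50000 nM in this assay, at which 1 of the 3 values shown sits, and the other two entries carry no number at all, so there is no measured step and no compound can be placed in order against another.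

Compound 4 `COc1ccc(/C(=C(/CCNC(=O)N2CCCCC2)c2ccccc2)c2ccccc2)cc1` is the next analogue: the change is piperidin-1-yl in place of morpholin-4-yl on a carbonyl carbon. Among the measured compounds shown here, since no measured step exists here, the only anchor is that compound 3 sits at the limit in this assay. No shift beyond the scatter is expected, and the step from compound 3 to compound 4 is expected to be a step that the limit leaves unreadable from compound 3 to compound 4. Compound 4 is expected to give about 60000 nM in this assay, with a range of 20000 nM to 200000 nM, and most likely to be reported again only as a limit rather than as a number.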

Compound 4, half-maximal inhibitory concentration: > 50000 nM
Compound 4: only a limit was reported; the forecaster's own chance of this, stated with the estimate: 80%; the middle value is on the limit's open side.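

In this assay compound 4 gives > 50000 nM, which is a limit and not a number. With compound 3 also recorded only as a limit, no step can be read between compound 3 and compound 4: the limit of > 50000 nM in this assay, at which 2 of the 4 values shown sit.

The compounds shown leave open how piperidin-1-yl and morpholin-4-yl on a carbonyl carbon compare in this assay, and whether any compound of this series gives a measured number there.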